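The source may report more compounds than this note shows. Statements on the series, on what has been measured and on what is new or still open speak of the compounds shown alone.

Measured compounds:
compound 1 `Cc1cc(-c2ccoc2)c2ncc(CSCCc3ccccc3)n2c1`: 100 ug/mL
compound 2 `Cc1cc(-n2cccc2)c2ncc(CSCCc3ccccc3)n2c1`: 100 ug/mL

In an ADME assay on HEL cells (Homo sapiens) for cytotoxicity, with a stated time of 3 days (on this read-out lower numbers stand for higher toxicity in this test and higher numbers for lower toxicity in this test), compound 1 gives 100 ug/mL. In this assay compound 2 gives 100 ug/mL. Among the compounds with values here, the one measured step, no change at the digits printed from compound 1 to compound 2 (within the scatter), swaps one five-membered aromatic ring for another on the shared core. On these numbers compound 2 stands level with compound 1, with no change beyond the scatter.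

Compound 3 `Cc1cc(C#N)c2ncc(CSCCc3ccccc3)n2c1` differs from compound 2 in one place: cyano in place of 1H-pyrrol-1-yl on an aromatic carbon. The measured step bears only loosely on this change, since it kept a five-membered ring where compound 3 carries a small cyano group instead. That step showed no change beyond the scatter, so for compound 3 a step of no change at the digits printed from compound 2 to compound 3 (within the scatter) in this assay is expected, that is, none beyond the scatter. Compound 3 is therefore estimated at 100 ug/mL, with a range from 30 ug/mL to 300 ug/mL.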

Compound 3, minimum cytotoxic concentration: >= 20 ug/mL
Compound 3: no number, only a limit; the forecaster's own chance of this, stated with the estimate: 25%; the middle value lies beyond the limit too.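

In this assay compound 3 gives >= 20 ug/mL, which is a limit and not a number. The steps from compound 1 and compound 2 to compound 3 cannot be read: the limit of >= 20 ug/mL in this assay, at which 1 of the 3 values shown sits. Still open, from the compounds shown here alone, is whether cyano, in place of either five-membered ring, changes the minimum cytotoxic concentration.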